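Bromo to Trifluoromethyl: The Same Swap on a Second Core

This account rests on a few compounds, and the source may have more. Where it says the series, first, only, none or still open, it means among the compounds named here.

Three compounds have been measured in a functional assay on HepG2 cells (Homo sapiens) for cytotoxicity, with a stated time of 24 h; on this read-out lower numbers stand for stronger inhibition and higher numbers for weaker inhibition:
compound 1, `COc1ccc(Cl)cc1C(=O)Nc1ccc(Br)cc1O`, 7980 nM;
compound 2, `COc1ccc(Cl)cc1C(=O)Nc1cc(Br)ccc1O`, 4090 nM;
compound 3, `COc1ccc(Cl)cc1C(=O)Nc1ccc(C(F)(F)F)cc1O`, 4910 nM.

Compound 1 and compound 2 are built from the same atoms joined differently; how their two cores differ is not broken down here. Their values lie within the scatter of each other, as do those of compound 2 and compound 3, so no order among the three can be read from them.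

Compound 3 arises from compound 1 by one change, (trifluoromethyl in place of bromo on an aromatic carbon). In this assay this gave a 1.6-fold lower number from compound 1 to compound 3 (0.21 log units; within the scatter).

Compound 4, `COc1ccc(Cl)cc1C(=O)Nc1cc(C(F)(F)F)ccc1O`, is not yet measured. It arises from compound 2 by trifluoromethyl in place of bromo on an aromatic carbon. Among the measured compounds shown here, this is the same kind of change as the one from compound 1 to compound 3, though the surroundings differ: here the place is meta to a large group and para to a hydroxy group, whereas in compound 1 it was meta to a hydroxy group and para to a large group.

Because the earlier step was a 1.6-fold lower number from compound 1 to compound 3 (0.21 log units; within the scatter), compound 4 is expected to show a 1.4-fold lower number from compound 2 to compound 4 (0.13 log units; within the scatter) in this assay. The estimate for compound 4 is 3000 nM, expected between 1200 nM and 8000 nM.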

Compound 4, half-maximal inhibitory concentration: 15400 nM
Beside the measured number, compound 4's estimate is 5.1-fold (0.71 log units) below it, outside the stated range (above it).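

In this assay, putting trifluoromethyl in place of bromo gave a 3.8-fold higher number from compound 2 to compound 4 (0.58 log units; beyond the scatter). Set beside the earlier step, this shows that the result of the change did not carry over from one core to the other, so a step measured on one of these cores is a poor guide to the same step on the other: the same change on two cores in this assay, a 1.6-fold lower number (0.21 log units; within the scatter) from compound 1 to compound 3 and a 3.8-fold higher number (0.58 log units; beyond the scatter) from compound 2 to compound 4, 6.1-fold (0.79 log units) apart, beyond the scatter of two such steps. It does not show why the two cores part ways, since two pairs of compounds cannot tell which feature of the cores matters, or predict what the same change would do on a third core.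

Still open, as far as these compounds go, is whether other groups in that same place, such as a nitrile, an amine or a carboxylic acid, would also give different results on the two cores. Also open, from the compounds shown here alone, is whether this gap between the cores would appear in any assay other than this cell test.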